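The source may hold more compounds than are shown below. What is called first, only, known or untested is meant among the compounds shown, and "the series" means these compounds.

Of the compounds shown here, three have so far been tested in an ADME assay on Huh-7 cells (Homo sapiens) for cytotoxicity, read by XTT assay, with a stated time of 3 days, tested at 200 uM; a lower number here means a stronger effect, a higher number a weaker effect of the compound at the concentration tested. Compound 1, `Fc1ccc(-c2cc(-c3ccc4cc(F)ccc4n3)nn2-c2ccccc2)cc1`, gives 89.7%. Compound 2, `COc1ccc(-c2cc(-c3ccc4cc(F)ccc4n3)nn2-c2ccccc2)cc1`, gives 93.7%. Compound 3, `COc1ccc(-n2nc(-c3ccc(F)cc3)cc2-c2ccc3cc(F)ccc3n2)cc1`, gives 52.6%, the lowest of the three, with the gap to each of the other two beyond the scatter. Compound 1 and compound 2 differ in a single place, (methoxy in place of fluoro on an aromatic carbon), and this step, a number 4 percentage points higher from compound 1 to compound 2 (within the scatter), lies within the scatter. How the core of compound 3 differs from the core of compound 1 is not broken down here.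

Compound 4, `COc1ccc(-c2cc(-c3ccc4cc(F)ccc4n3)n(-c3ccc(OC)cc3)n2)cc1`, has not yet been measured in this assay. It differs from compound 3 by methoxy in place of fluoro on an aromatic carbon, which is the same change as that from compound 1 to compound 2, at a place described in the same words. Because the step of a number 4 percentage points higher from compound 1 to compound 2 (within the scatter) stayed within the scatter, a similarly small step is expected here too, estimated as a number 4.4 percentage points higher from compound 3 to compound 4 (within the scatter), although this rests on a single earlier example. The expected value for compound 4 is therefore 57%, with a likely range from 40% to 80%.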

Compound 4, a percentage reported as activity, at one concentration (the size of the read-out at that concentration, not a potency): 98.4%
The estimate for compound 4 lay 41.4 percentage points below the measured number, and the stated range ends below it.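

In this assay, replacing fluoro with methoxy, which turns a 4-fluorophenyl into a 4-methoxyphenyl, gives a large step, a number 45.8 percentage points higher from compound 3 to compound 4 (beyond the scatter). The size of this step does not carry over from one core to the other, as the two examples of the same change show: the same change on two cores in this assay, a number 4 percentage points higher (within the scatter) from compound 1 to compound 2 and a number 45.8 percentage points higher (beyond the scatter) from compound 3 to compound 4, 41.8 percentage points apart, beyond the scatter of two such steps. The small step on the core of compound 1 therefore gave no reliable guide to the step on the core of compound 3, but two pairs do not explain the difference, show which part of the cores matters, or give a rule for any further core.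

The compounds shown leave open how other groups at this place would behave on these two cores, such as an amine, a carboxylic acid or a longer chain like butoxy. They also leave open whether the change from fluoro to methoxy would give a small step, a large step or something in between on a third core.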